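The source may hold more compounds than are shown below. What is called first, only, known or untested is meant among the compounds shown, and "the series" means these compounds.

Compounds measured in an assay for inhibition of mitogen-activated protein kinase kinase kinase 14 (Homo sapiens), read by luminescence and ADP-Glo, with a stated time of 120 min, in the presence of a further agent that is not named here; on this read-out lower numbers stand for stronger inhibition and higher numbers for weaker inhibition:
- compound 1 `CC(O)(C#Cc1cccc(Nc2ncnc3[nH]ccc23)c1)c1nccs1`: 1640 nM
- compound 2 `CC(O)(C#Cc1ccc(N2CCCC2)c(Nc2ncnc3[nH]ccc23)c1)c1nccs1`: 107 nM

Among the measured compounds shown here, compound 2 stands lowest of the two numbers in this assay; its only neighbour is compound 1, which sits a good deal higher. For the measured compounds named here, the single measured step, a 15-fold lower number from compound 1 to compound 2 (1.19 log units; beyond the scatter), was a large one and lies beyond the scatter. That step, however, adds a ring where a hydrogen stood, whereas the change now in view exchanges one ring for another. Compound 3 `CC(O)(C#Cc1ccc(N2CCN(S(=O)(=O)C3CC3)CC2)c(Nc2ncnc3[nH]ccc23)c1)c1nccs1` differs from compound 2 by 4-(cyclopropylsulfonyl)piperazin-1-yl in place of pyrrolidin-1-yl on an aromatic carbon. Going by the values given here, no measured step speaks to this kind of exchange, so the direction and size of the move cannot be read from what is known; the step is expected to stay within the scatter, a 1.1-fold higher number from compound 2 to compound 3 (0.05 log units; within the scatter). Compound 3 is therefore estimated at 120 nM, with a range from 30 nM to 500 nM.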

Compound 3, half-maximal inhibitory concentration: 16.2 nM
Compound 3: middle estimate off by 7.4-fold (0.87 log units), on the high side; the measured number lies below the stated range.
By their numbers in this assay, from the lowest: compound 3; then compound 2; then compound 1.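

At this position, para to a 3-hydroxy-3-(1,3-thiazol-2-yl)but-1-yn-1-yl group, the number in this assay can fall further than pyrrolidin-1-yl took it: exchanging that ring for 4-(cyclopropylsulfonyl)piperazin-1-yl gives a 6.6-fold lower number from compound 2 to compound 3 (0.82 log units; beyond the scatter). Set against hydrogen at the same place, the entering group gives a 100-fold lower number from compound 1 to compound 3 (2.01 log units; beyond the scatter), so a much larger group is accepted here and the pyrrolidin-1-yl result did not mark the limit of the gain. Nothing measured here accounts for this gain.

The compounds shown do not separate the contributions of the cyclopropyl ring, the sulfonyl group and the piperazine ring to the step. Going by these compounds, how a piperazine with a free amine, a methylsulfonyl piperazine or a morpholine ring would read at this position remains open.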